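Swapping chloro for methoxy on the carbonyl-bearing ring

A few compounds are considered here, and "the series" means these few. Any claim that something is new, unique, unknown or untested is made for them only; others in the source may bear on it.

Three compounds have been measured in a functional assay on MKN-74 cells (Homo sapiens) for antiproliferative activity, with a stated time of 24 h; on this read-out lower numbers stand for stronger inhibition and higher numbers for weaker inhibition:
Compound 1 `NC(=O)c1c(NC(=O)c2ccccc2Cl)sc2c1CCN(Cc1ccccc1F)C2` gives 12900 nM.
Compound 2 `COc1ccccc1NC(=S)N1CCc2c(sc(NC(=O)c3ccccc3Cl)c2C(N)=O)C1` gives 35200 nM.
Compound 3 `NC(=O)c1c(NC(=O)c2ccccc2Cl)sc2c1CCN(C(=S)Nc1ccccc1-c1ccccc1)C2` gives 25800 nM.

Compound 2 has the highest number of the three: the step of a 2.7-fold higher number from compound 1 to compound 2 (0.44 log units; beyond the scatter) lies beyond the scatter, whereas the step of a 1.4-fold lower number from compound 2 to compound 3 (0.13 log units; within the scatter) does not. Compound 4 `COc1ccccc1NC(=S)N1CCc2c(sc(NC(=O)c3ccccc3OC)c2C(N)=O)C1` differs from compound 2 in one place: methoxy in place of chloro on an aromatic carbon. Going by the values given here, both measured steps alter the group on the amine nitrogen in a ring, and neither touches the (2-chlorophenyl)carbonyl group, so no measured step bears directly on this change. Among the compounds with values here, with no precedent in these data, the expectation is a step of a 1.1-fold higher number from compound 2 to compound 4 (0.06 log units; within the scatter) in this assay, that is, nothing beyond the scatter, but with a wide range in either direction. Compound 4 is therefore estimated at 40000 nM in this assay, expected to fall between 15000 nM and 110000 nM.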

Compound 4, half-maximal inhibitory concentration: > 50000 nM
Compound 4: a limit, no number; the forecaster's own chance of this, stated with the estimate: 15%; middle value at least 1.2-fold (0.09 log units) from the limit.
By their numbers in this assay, from the lowest: compounds 1, 3 and 2 (each within the scatter of the next, the first and the last beyond it). At a limit, above all of these: compound 4.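

This is the first change in the compounds shown to the (2-chlorophenyl)carbonyl group rather than to the group on the amine nitrogen in a ring. In this assay, compound 4 is reported only as a limit, not as a number: the limit of > 50000 nM in this assay, at which 1 of the 4 values shown sits. From the compounds shown here alone, the change from chloro to methoxy in this position, read as an at least 1.4-fold higher number from compound 2 to compound 4 (0.15 log units; that floor lies within the scatter), brings no gain in inhibition, yet this floor alone does not establish a loss, and the size of any true loss stays unknown.

Going by these compounds, whether a fluoro, a methyl or an amine in the same place would give a lower number than chloro remains open. Also open, on these data alone, is whether methoxy here would act the same way with the 2-fluorobenzyl group of compound 1 on the ring nitrogen.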